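Piperidin-1-yl in place of dimethylamino: working notes on compound 3

The compounds below may be only part of what the source reports. "The series", "measured", "known", "first", "only" and "open" are said of these compounds alone.

Compound 1 `CN(C)C(=O)[C@H]1CCC[C@@H](c2cccc(-n3ncc(C(=O)O)c3C3CC3)c2)C1` gives 1.7 in a physicochemical assay for lipophilicity, read by HPLC, at pH 2; on this read-out higher numbers stand for higher lipophilicity and lower numbers for lower lipophilicity
Compound 2 `CCCC1CCCCN1C(=O)c1cccc(-c2cccc(-n3ncc(C(=O)O)c3C3CC3c3ccccn3)c2)c1` gives 3.1 in this assay

Compound 1 holds the lower of the two numbers, and the gap up to compound 2 lies beyond the scatter. Compound 3 `O=C(O)c1cnn(-c2cccc([C@@H]3CCC[C@H](C(=O)N4CCCCC4)C3)c2)c1C1CC1` is still unmeasured and differs from compound 1 in one place: piperidin-1-yl in place of dimethylamino on a carbonyl carbon. In words, piperidin-1-yl stands in place of dimethylamino on a carbonyl carbon. Among the measured compounds shown here, no measured pair shows this change alone, so its size in this assay remains a judgement. The expectation rests on the change itself, with compound 1 at 1.7 as the starting value. A moderate rise beyond the scatter is expected, and the estimated step of a number 0.60 log units higher from compound 1 to compound 3 (beyond the scatter) is the working figure. For compound 3 the estimated value is 2.3, with 2 to 2.7 as the expected range.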

Compound 3, distribution coefficient: 2.7
Estimate against measurement, compound 3: 0.40 log units below, within the range that was stated.
By their numbers in this assay, from the lowest: compound 1; then compound 3; then compound 2.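

Among the compounds shown here, with a number 1.00 log units higher from compound 1 to compound 3 (beyond the scatter) in this assay, piperidin-1-yl in place of dimethylamino on a carbonyl carbon now has a measured size, which no earlier pair could provide. The two groups have the same counts of hydrogen-bond donors and acceptors and neither carries a net charge, so the structural difference lies in the added carbon atoms and the six-membered non-aromatic ring. The data give no measured basis for assigning the step to either feature or for explaining its size.

A single pair cannot show whether the step would carry over to a carbonyl carbon in another core. Also open, going by these compounds, is how pyrrolidin-1-yl, morpholin-4-yl or diethylamino would read at this place, which would help separate ring size, ring closure and the presence of a ring oxygen.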